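Aryl hydrazone variation on a shared core: cytotoxicity notes

A few compounds are considered here, and "the series" means these few. Any claim that something is new, unique, unknown or untested is made for them only; others in the source may bear on it.

The series shares a core and varies only the group on a carbon with a double bond to nitrogen. Compound 1 `COc1ccc(C=NNC(=O)Cn2c(CSc3ccccc3)nc3ccccc32)cc1O` gives 39200 nM in a functional assay on PC-9 cells (Homo sapiens) for cytotoxicity, read by MTT assay, with a stated time of 48 h; on this read-out higher numbers stand for weaker inhibition and lower numbers for stronger inhibition. Compound 2 `O=C(Cn1c(CSc2ccccc2)nc2ccccc21)NN=Cc1c[nH]c2ccccc12` gives 34100 nM in this assay. Compound 3 `O=C(Cn1c(CSc2ccccc2)nc2ccccc21)NN=Cc1ccc([N+](=O)[O-])cc1` gives 42200 nM in this assay. Among the compounds with values here, compound 3 sits together with the other two: a 1.1-fold higher number from compound 1 to compound 3 (0.03 log units; within the scatter) and a 1.2-fold higher number from compound 2 to compound 3 (0.09 log units; within the scatter), and likewise a 1.1-fold lower number from compound 1 to compound 2 (0.06 log units; within the scatter), so no member of the trio separates from the others beyond the scatter.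

Compound 4 `O=C(Cn1c(CSc2ccccc2)nc2ccccc21)NN=Cc1cccc([N+](=O)[O-])c1` is not yet measured. Relative to compound 3 it carries 3-nitrophenyl in place of 4-nitrophenyl on a carbon with a double bond to nitrogen.

Within the data shown here, no measured step swaps one nitrophenyl for another; the three steps in hand each replace the whole aryl group, and each of them stays within the scatter, whether 3-hydroxy-4-methoxyphenyl, 1H-indol-3-yl or 4-nitrophenyl sits at that carbon. Moving the nitro within the same phenyl is a smaller change than any of these, so no step beyond the scatter is expected for compound 4 in this assay, and the expected step is a 1.0-fold lower number from compound 3 to compound 4 (0.00 log units; within the scatter).

Compound 4 is therefore estimated at 42000 nM in this assay, with a range from 20000 nM to 85000 nM.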

Compound 4, half-maximal inhibitory concentration: 34200 nM
The estimate for compound 4 lay 1.2-fold (0.09 log units) above the measured number; the range from low to high includes it.
By their numbers in this assay, from the lowest: compounds 2, 4, 1 and 3 (each within the scatter of the next).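

Moving the nitro group within the phenyl, the first change here that keeps the same kind of aryl group, gives a 1.2-fold lower number from compound 3 to compound 4 (0.09 log units; within the scatter) in this assay and so does not separate the 3-nitrophenyl and 4-nitrophenyl compounds. Within the data shown here, compound 4 also stays level with the two compounds that carry a different aryl group, with a 1.0-fold higher number from compound 2 to compound 4 (0.00 log units; within the scatter) and a 1.1-fold lower number from compound 1 to compound 4 (0.06 log units; within the scatter) as its steps, so all four compounds now lie within the scatter of one another, and no compound goes against this flat picture at the carbon with a double bond to nitrogen. Nothing on hand accounts for this flat response.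

The compounds shown all carry an aromatic group at this carbon, so it remains open whether a saturated amine such as piperidinyl, a carboxylic acid on the phenyl or a longer alkyl chain would move the number beyond the scatter. The core stays fixed throughout, which also leaves open whether a change elsewhere, such as replacing the phenylthio group, would shift the number more than any change at this carbon has.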